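A Thioester Swap on a Glycoside Core

The compounds below may be only part of what the source reports. "The series", "measured", "known", "first", "only" and "open" are said of these compounds alone.

Compound 1 `C/C=C1/[C@H](O[C@@H]2O[C@H](CO)[C@@H](O)[C@H](O)[C@H]2O)OC=C(C(=O)OC)[C@H]1CC(=O)O` and compound 2 `C#CCOC(=O)C[C@@H]1C(C(=O)OC)=CO[C@@H](O[C@@H]2O[C@H](COC(C)=O)[C@@H](OC(C)=O)[C@H](OC(C)=O)[C@H]2OC(C)=O)/C1=C/C` share the same glycosylated core and were both tested in a functional assay on SK-BR-3 cells (Homo sapiens) for antiproliferative activity, read by MTT assay, with a stated time of 72 h; a lower number here means a stronger inhibitor, a higher number a weaker inhibitor. In this assay compound 1 gives only a limit, > 15000 nM, rather than a number. Compound 2 likewise reaches only the limit of this assay, > 15000 nM. Both results therefore sit at the limit of > 15000 nM in this assay, at which 2 of the 2 values shown sit, so neither compound shows growth inhibition that could be quantified within the tested range. Compound 3 `C/C=C1/[C@H](O[C@@H]2O[C@H](COC(C)=O)[C@@H](OC(C)=O)[C@H](OC(C)=O)[C@H]2OC(C)=O)OC=C(C(=O)OC)[C@H]1CC(=O)SCCc1ccccc1` is the next compound for this assay. Compared with compound 2, it carries phenethylsulfanyl in place of propargyloxy on a carbonyl carbon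

For the measured compounds named here, no measured step connects two compounds here, so the expected size of the change rests on the two limits alone. Because compound 2 sits at the limit > 15000 nM, its true potency is not known and the starting point is uncertain. The expected step that the limit leaves unreadable from compound 2 to compound 3 amounts to no change beyond the usual scatter. Compound 3 is accordingly estimated at 20000 nM, with a plausible range from 5000 nM to 80000 nM, and a considerable chance that only a limit is reported once more.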

Compound 3, half-maximal inhibitory concentration: > 15000 nM
Compound 3 ended at the assay's limit (the forecaster's own chance of this, stated with the estimate: 70%); the middle value is on the limit's open side.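

In this assay compound 3 gives > 15000 nM, a limit and not a number. Compound 2 also gives only a limit, so the step between these two compounds cannot be read. The compounds shown leave open what structure on the shared core would bring growth inhibition into a measurable range, as all share one result: the limit of > 15000 nM in this assay, at which 3 of the 3 values shown sit.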